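This account rests on a few compounds, and the source may have more. Where it says the series, first, only, none or still open, it means among the compounds named here.

Compound 1, `CN1C[C@H](Nc2nc3cc[nH]c3c(=O)n2C)C[C@H](c2cccc(Br)c2)C1`, gives 7.5 degrees C in an assay on isolated protein for binding affinity to histone acetyltransferase KAT2B (Homo sapiens), read by fluorescence, tested at 10 uM (a lower number here means that the compound stabilises the target less, a higher number that the compound stabilises the target more against heat), the higher of the two values recorded; compound 2, `CCCCc1ccc([C@H]2C[C@@H](Nc3nc4cc[nH]c4c(=O)n3C)CN(C)C2)cc1`, gives 4.6 degrees C in this assay, a gap beyond the scatter. Compound 3, `CN1C[C@H](Nc2nc3cc[nH]c3c(=O)n2C)C[C@H](c2ccccc2)C1`, differs from compound 1 only by hydrogen in place of bromo on an aromatic carbon. Among the compounds with values here, no measured pair isolates this change, so its size is not known directly. Loss of the bromo group is expected to lower the shift by a modest amount, from compound 1 to compound 3 estimated as a number 2.0 degrees C lower from compound 1 to compound 3 (beyond the scatter). Compound 3 is therefore expected to give 5.5 degrees C in this assay, within a range of 3.5 degrees C to 7.5 degrees C.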

Compound 3, shift of the target's melting temperature: 6.3 degrees C
Estimate against measurement, compound 3: 0.80 degrees C below, and the stated range covers the measured number.
By their numbers in this assay, from the lowest: compound 2; then compound 3; then compound 1.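

In this assay, hydrogen in place of bromo on an aromatic carbon costs a modest part of the shift (a number 1.2 degrees C lower from compound 1 to compound 3 (beyond the scatter)), and compound 3, with a plain phenyl, still gives 6.3 degrees C. Hydrogen in place of butyl has the opposite sign (a number 1.7 degrees C higher from compound 2 to compound 3 (beyond the scatter)), so a group on this ring can either add to the shift or take from it. No measurement given here accounts for either step. From the compounds shown here alone, it remains open whether chlorine or fluorine at the bromo position would match bromo, and whether a methyl or ethyl chain would fare better than butyl.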